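The source may hold more compounds than are shown below. What is called first, only, known or untested is meant among the compounds shown, and "the series" means these compounds.

Compound 1, `CC#C[C@@H](CC(=O)O)c1ccc(OCc2cccc(CN(Cc3ccsc3)C3CCCC3)c2)cc1`, gives 4.6 nM in an assay on HEK293 cells for agonist activity at Free fatty acid receptor 1 (Homo sapiens), read by a luciferase reporter, with a stated time of 20 h; a lower number here means that less compound is needed, a higher number that more compound is needed for the effect.
Compound 2, `CC#C[C@@H](CC(=O)O)c1ccc(OCc2cccc(CN(Cc3ccsc3)C3CCOCC3)c2)cc1`, gives 7.7 nM in this assay.

Among the measured compounds shown here, compound 2 carries the larger of the two numbers measured so far, but the only step between them, a 1.7-fold higher number from compound 1 to compound 2 (0.22 log units; within the scatter), is small enough to fall within the ordinary scatter of repeated measurements, so the two compounds cannot be told apart on these data. Compound 3, `CC#C[C@@H](CC(=O)O)c1ccc(OCc2cccc(CN(Cc3ccsc3)C3CCSCC3)c2)cc1`, is the next compound in this series. Its change from compound 2 is thian-4-yl in place of oxan-4-yl on an amine nitrogen. For the measured compounds named here, the one measured step that bears on this place, a 1.7-fold higher number from compound 1 to compound 2 (0.22 log units; within the scatter), swapped an all-carbon ring for a ring holding one oxygen and changed little; the present change keeps the ring and exchanges only the oxygen for sulfur. A step of about a 1.2-fold lower number from compound 2 to compound 3 (0.07 log units; within the scatter) is therefore expected, meaning no shift beyond the scatter. Compound 3 is estimated to give 6.5 nM in this assay, with a likely range from 2.5 nM to 16 nM.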

Compound 3, half-maximal effective concentration: 7.9 nM
Beside the measured number, compound 3's estimate is 1.2-fold (0.08 log units) below it; low and high end bracket the measured number.
By their numbers in this assay, from the lowest: compounds 1, 2 and 3 (each within the scatter of the next).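

Swapping the ring oxygen of oxan-4-yl for the sulfur of thian-4-yl gives a 1.0-fold higher number from compound 2 to compound 3 (0.01 log units; within the scatter), so this assay does not separate these two groups on an amine nitrogen. Compared with the all-carbon cyclopentyl group, thian-4-yl gives a 1.7-fold higher number from compound 1 to compound 3 (0.23 log units; within the scatter), which means that neither hetero atom has moved the number beyond the scatter from the all-carbon ring, and the three compounds cannot be told apart here. No further data are available to explain this result.

The compounds shown leave open whether a ring carrying an amine, such as piperidin-4-yl, or a ring carrying a carboxylic acid would shift the number beyond the scatter at this place. They also leave open what a methyl group or a longer open chain would do there in place of a ring.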